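A Phenyl Cap Replacing Methoxy in a Trifluoromethyl Diol Series

The source may hold more compounds than are shown below. What is called first, only, known or untested is meant among the compounds shown, and "the series" means these compounds.

Measured so far:
compound 1, `O=C(CCCCCCNC(=O)C(O)(O)C(F)(F)F)Nc1ccc(F)cc1`, 7570 nM
compound 2, `COc1ccc(NC(=O)CCCCCCNC(=O)C(O)(O)C(F)(F)F)cc1`, 4520 nM

Both compounds share one core and differ only in the group on the aromatic ring. In a functional assay on HCT-116 cells (Homo sapiens) for inhibition, read by colorimetric assay, with a stated time of 3 days (a higher number here means a weaker inhibitor, a lower number a stronger inhibitor), compound 1 gives 7570 nM, and compound 2 gives 4520 nM. The step of a 1.7-fold lower number from compound 1 to compound 2 (0.22 log units; within the scatter) lies within the scatter, so compound 2 and compound 1 cannot be told apart on these numbers.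

Compound 3, `O=C(CCCCCCNC(=O)C(O)(O)C(F)(F)F)Nc1ccc(-c2ccccc2)cc1`, is not yet measured. Its change from compound 2 is phenyl in place of methoxy on an aromatic carbon. Within the data shown here, the only measured step, a 1.7-fold lower number from compound 1 to compound 2 (0.22 log units; within the scatter), concerns a small group at the same place and moved the number little. Among the measured compounds shown here, a phenyl ring entering is a larger change, and no measured step covers it, so the expectation rests on weak ground. Compound 3 is expected at 2500 nM, with a range of 800 nM to 8000 nM, which means an estimated 1.8-fold lower number from compound 2 to compound 3 (0.26 log units; within the scatter).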

Compound 3, half-maximal inhibitory concentration: 4730 nM
The estimate for compound 3 lay 1.9-fold (0.28 log units) below the measured number; low and high end bracket the measured number.
By their numbers in this assay, from the lowest: compounds 2, 3 and 1 (each within the scatter of the next).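

In this assay, phenyl on this aromatic carbon, para to a large group, gives a 1.0-fold higher number from compound 2 to compound 3 (0.02 log units; within the scatter), and set against fluoro it gives a 1.6-fold lower number from compound 1 to compound 3 (0.20 log units; within the scatter). The earlier pair covered only fluoro and methoxy, whereas this result shows that a six-membered aromatic ring of carbon only, with 6 heavy atoms in place of the 2 of methoxy, also leaves the number within the scatter, so the three groups cannot be told apart here. Nothing available bears on why the number stays so flat across these groups.

From the compounds shown here alone, whether an amine or a carboxylic acid at this same aromatic carbon would move the number remains open. So does the part played by the chain and the trifluoromethyl diol end, which all three compounds share, and a longer chain or a hydroxamic acid in place of that end could speak to it.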